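Compound 4: an open-chain amine in place of piperidine

A few compounds are considered here, and "the series" means these few. Any claim that something is new, unique, unknown or untested is made for them only; others in the source may bear on it.

Compound 1, `O=C(CN1CCCCC1)Nc1ccc(-c2nc3cc(C(F)(F)F)ccc3[nH]2)cc1`: 12000 nM
Compound 3, `O=C(CN1CCCCC1)Nc1ccc(-c2nc3ccccc3[nH]2)cc1`: 31000 nM
Compound 2, `Cn1c(-c2ccc(NC(=O)CN3CCCCC3)cc2)nc2cc(C(F)(F)F)ccc21`: a limit of the assay, > 100000 nM

In an ADME assay on BHK cells (Mesocricetus auratus) for cytotoxicity, read by MTT assay, with a stated time of 96 h (on this read-out lower numbers stand for higher toxicity in this test and higher numbers for lower toxicity in this test), compound 1 gives 12000 nM, the lowest of the two numbers shown. Compound 3 gives 31000 nM, which is a 2.6-fold higher number from compound 1 to compound 3 (0.41 log units; beyond the scatter). For compound 2 the read-out is only a limit of the assay, > 100000 nM. The step there is an at least 8.3-fold higher number from compound 1 to compound 2 (0.92 log units; beyond the scatter). Compound 4, `CCN(CC)CC(=O)Nc1ccc(-c2nc3cc(C(F)(F)F)ccc3[nH]2)cc1`, differs from compound 1 in one place: diethylamino in place of piperidin-1-yl on a saturated chain carbon bound to a carbonyl carbon. Neither measured step touches this amine; one concerns the trifluoromethyl and the other the methyl on an aromatic nitrogen, and both moved the number upward. With no direct guide for the amine, the step of a 1.3-fold higher number from compound 1 to compound 4 (0.10 log units; within the scatter) is expected to stay within the scatter. Compound 4 is estimated at 15000 nM, between 6000 nM and 40000 nM.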

Compound 4, half-maximal cytotoxic concentration: 23000 nM
Estimate against measurement, compound 4: 1.5-fold (0.19 log units) below, and the stated range covers the measured number.
By their numbers in this assay, from the lowest: compounds 1, 4 and 3 (each within the scatter of the next, the first and the last beyond it). At a limit, above all of these: compound 2.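

Going by these compounds alone, on a saturated chain carbon bound to a carbonyl carbon, the first change at this amine, diethylamino in place of piperidin-1-yl, gives in this assay a 1.9-fold higher number from compound 1 to compound 4 (0.28 log units; within the scatter) and so, unlike the two earlier steps, stays inside the scatter. For these two compounds, then, the closed six-membered ring is not needed to keep the number in this range. Nothing given here offers a cause for this step.

From the compounds shown here alone, whether morpholin-4-yl, dimethylamino or a longer chain carrying the amine would read alike at this place stays open.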